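A few compounds are considered here, and "the series" means these few. Any claim that something is new, unique, unknown or untested is made for them only; others in the source may bear on it.

Measured so far:
compound 1, `Cc1nc(S(C)(=O)=O)ccc1Oc1ncnc(OC2CCN(C(=O)OC(C)(C)C(F)(F)F)CC2)c1F`, gives 79% in a functional assay on isolated protein for inhibition of Glucose-dependent insulinotropic receptor (Rattus norvegicus), read by HTRF and cAMP accumulation; a higher number here means a larger maximal response, a lower number a smaller maximal response
compound 2, `Cc1nc(S(C)(=O)=O)ccc1Oc1ncnc(OC2CCN(C(=O)OC(C)(C)CF)CC2)c1F`, gives 95% in this assay
compound 3, `Cc1nc(S(C)(=O)=O)ccc1Oc1ncnc(OC2CCN(C(=O)OC(C)F)CC2)c1F`, gives 68% in this assay

Compound 3 stands lowest of the three numbers: the maximal response is a number 11 percentage points lower from compound 1 to compound 3 (beyond the scatter) and a number 27 percentage points lower from compound 2 to compound 3 (beyond the scatter), both beyond the scatter. Compound 4, `Cc1nc(S(C)(=O)=O)ccc1Oc1ncnc(OC2CCN(C(=O)C(C)(F)F)CC2)c1F`, has not yet been measured. (a group of 4 heavy atoms (2 carbon, 2 fluorine; no ring) in place of a group of 4 heavy atoms (2 carbon, 1 oxygen, 1 fluorine; no ring), on a carbonyl carbon). Among the compounds with values here, every measured step changes only the group on the oxygen of the carbamate, keeping that oxygen in place; none removes it as this change does, so no step speaks to it directly. The nearest guides are a number 16 percentage points higher from compound 1 to compound 2 (beyond the scatter) and a number 27 percentage points lower from compound 2 to compound 3 (beyond the scatter), which show that small changes in this region move the maximal response by modest amounts in either direction. A step of similar size at most is therefore expected, its direction uncertain, with a slight lean upward because compound 3 gives 68%, the lowest point so far. Compound 4 is estimated at 75%, between 55% and 95%, which is expected to mean a number 7 percentage points higher from compound 3 to compound 4 (within the scatter).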

Compound 4, largest response reached (reported as efficacy), in percent of the reference or control that the assay uses: 87%
For compound 4 the middle estimate is 12 percentage points below the measured one; the range from low to high includes it.
By their numbers in this assay, from the lowest: compound 3; then compounds 1, 4 and 2 (each within the scatter of the next, the first and the last beyond it).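

Removing the oxygen of the carbamate does not cost maximal response in this assay: with 1,1-difluoroethyl directly on the carbonyl carbon, the change gives a number 19 percentage points higher from compound 3 to compound 4 (beyond the scatter). The new compound also sits close to the two larger carbamates, with a number 8 percentage points lower from compound 2 to compound 4 (within the scatter) and a number 8 percentage points higher from compound 1 to compound 4 (within the scatter), so among these four compounds a high response does not depend on that oxygen, while compound 3 is the one carbamate that falls clearly short of compound 2. Nothing measured here explains these differences.

Going by these compounds, it remains open whether an amine nitrogen in place of the oxygen, giving a urea, or a cyclopropyl group on the carbonyl carbon would keep the response. Equally open, on these data alone, is whether plain ethyl at that place would match 1,1-difluoroethyl.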